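Toward compound 4: a chloro-fluorophenyl amide on the shared core

A few compounds are considered here, and "the series" means these few. Any claim that something is new, unique, unknown or untested is made for them only; others in the source may bear on it.

Measured so far in a functional assay on Raji cells (Homo sapiens) for antiproliferative activity, read by CCK-8 assay, with a stated time of 72 h; a lower number here means a stronger inhibitor, a higher number a weaker inhibitor:
Compound 1, `CCOC(=O)c1sc(-c2cccc(NC(=O)c3ccccc3F)c2)nc1Nc1ccc(N2CCN(C)CC2)cc1`, gives 9270 nM.
Compound 2, `CN1CCN(c2ccc(Nc3nc(-c4cccc(NC(=O)c5cccc(F)c5)c4)sc3C(=O)O)cc2)CC1`, gives 35100 nM.
Compound 3, `CN1CCN(c2ccc(Nc3nc(-c4cccc(NC(=O)c5ccccc5F)c4)sc3C(=O)O)cc2)CC1`, gives 13900 nM.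

Compound 3 sits second highest of the three numbers; its gap to compound 1, a 1.5-fold higher number from compound 1 to compound 3 (0.18 log units; within the scatter), is within the scatter, while the step of a 2.5-fold lower number from compound 2 to compound 3 (0.40 log units; beyond the scatter) is beyond it. Compound 4, `CN1CCN(c2ccc(Nc3nc(-c4cccc(NC(=O)c5ccc(F)c(Cl)c5)c4)sc3C(=O)O)cc2)CC1`, differs from compound 3 in one place: 3-chloro-4-fluorophenyl in place of 2-fluorophenyl on a carbonyl carbon. For the measured compounds named here, the only step that bears on this is a 2.5-fold lower number from compound 2 to compound 3 (0.40 log units; beyond the scatter), where the aryl pattern on the carbonyl carbon changed; it was modest. Compound 4 carries no substituent at the position that helped compound 3, so a modest move toward a higher number is expected, a 1.8-fold higher number from compound 3 to compound 4 (0.25 log units; within the scatter). Compound 4 is therefore estimated at 25000 nM, within 9000 nM to 70000 nM.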

Compound 4, half-maximal inhibitory concentration: 8740 nM
The estimate for compound 4 lay 2.9-fold (0.46 log units) above the measured number; the whole stated range lies above it.
By their numbers in this assay, from the lowest: compounds 4, 1 and 3 (each within the scatter of the next); then compound 2.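

In this assay, this place on the carbonyl carbon accepts 3-chloro-4-fluorophenyl in place of 2-fluorophenyl, with a 1.6-fold lower number from compound 3 to compound 4 (0.20 log units; within the scatter), so a 2-fluorophenyl group is not needed to hold the number there. Set against the 3-fluorophenyl amide, the same group gives a 4.0-fold lower number from compound 2 to compound 4 (0.60 log units; beyond the scatter), a modest step. No measurement here accounts for either step. The compounds shown leave open how an amine or a longer chain would fare on this carbonyl carbon in place of the aryl group. They also leave open whether 3-chloro-4-fluorophenyl gives a similar number alongside the ethyl ester of compound 1.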